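A few compounds are considered here, and "the series" means these few. Any claim that something is new, unique, unknown or untested is made for them only; others in the source may bear on it.

Of the compounds shown here, three built on one shared core have been measured in an assay on isolated protein with Bile acid receptor (Homo sapiens) as the target; a higher number here means that more compound is needed for the effect, a lower number that less compound is needed. Compound 1 `COC(=O)/C=C/c1cccc(N(Cc2ccc(/C=C/c3cccc(C(F)(F)F)c3)cc2)C(=O)C(C)C)c1` carries a 3-(trifluoromethyl)phenyl group on a double-bonded chain carbon bound to a double-bonded chain carbon, and in this assay compound 1 gives 267 nM. Compound 2 `COC(=O)/C=C/c1cccc(N(Cc2ccc(/C=C/c3c(F)cccc3F)cc2)C(=O)C(C)C)c1` gives 108 nM, and compound 3 `COC(=O)/C=C/c1cccc(N(Cc2ccc(/C=C/c3c(C)cc(C)cc3C)cc2)C(=O)C(C)C)c1` gives 149 nM. Compound 3 therefore stands second highest of the three numbers: its nearest neighbour is compound 2, the step of a 1.4-fold higher number from compound 2 to compound 3 (0.14 log units; within the scatter) lying within the scatter, and its furthest is compound 1, the step of a 1.8-fold lower number from compound 1 to compound 3 (0.25 log units; within the scatter) also within the scatter. Among the compounds with values here, the only step that clears the scatter is a 2.5-fold lower number from compound 1 to compound 2 (0.39 log units; beyond the scatter).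

Compound 4 `COC(=O)/C=C/c1cccc(N(Cc2ccc(/C=C/c3ccc(F)cc3)cc2)C(=O)C(C)C)c1` differs from compound 3 in a single place: 4-fluorophenyl in place of 2,4,6-trimethylphenyl on a double-bonded chain carbon bound to a double-bonded chain carbon. This is one more variant of the same aryl group, and the three variants measured so far stay close together, none of them separated from compound 3 by more than the scatter. On that basis the estimated step of a 1.1-fold higher number from compound 3 to compound 4 (0.06 log units; within the scatter) is expected to stay within the scatter. Compound 4 is accordingly estimated to give about 170 nM in this assay, with a plausible range from 75 nM to 380 nM.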

Compound 4, half-maximal effective concentration: 120 nM
Beside the measured number, compound 4's estimate is 1.4-fold (0.15 log units) above it; measured number inside the range.
By their numbers in this assay, from the lowest: compounds 2, 4, 3 and 1 (each within the scatter of the next, the first and the last beyond it).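

In this assay, the 4-fluorophenyl group, with 7 heavy atoms against the 9 of 2,4,6-trimethylphenyl, gives a result that cannot be told apart from either of its two nearest comparisons: a 1.2-fold lower number from compound 3 to compound 4 (0.09 log units; within the scatter) and a 1.1-fold higher number from compound 2 to compound 4 (0.05 log units; within the scatter) both lie within the scatter. This place on the double-bonded chain therefore accommodates a single fluorine, two fluorines or three methyl groups on the phenyl ring with no separation among these three compounds, and neither the size of the group nor the number of its substituents orders them. Against the 3-(trifluoromethyl)phenyl group, a 2.2-fold lower number from compound 1 to compound 4 (0.35 log units; beyond the scatter) now joins a 2.5-fold lower number from compound 1 to compound 2 (0.39 log units; beyond the scatter) as a second modest step beyond the scatter, although compound 3 goes against a clean split, since a 1.8-fold lower number from compound 1 to compound 3 (0.25 log units; within the scatter) stays within it.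

Nothing available gives a reason for these numbers. The compounds shown leave open how this place would respond to an amine or a carboxylic acid on the phenyl ring, since every aryl group here carries only fluorine, methyl or trifluoromethyl.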